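Swapping 4-hydroxyphenyl for furan-2-yl in compound 3

A few compounds are considered here, and "the series" means these few. Any claim that something is new, unique, unknown or untested is made for them only; others in the source may bear on it.

In a functional assay on SGC-7901 cells (Homo sapiens) for antiproliferative activity, read by MTT assay, with a stated time of 48 h (a higher number here means a weaker inhibitor, a lower number a stronger inhibitor), compound 3 (`Oc1ccc(-c2nnc(SCc3ccc(Cl)nc3)o2)cc1`) reads > 20 ug/mL, which is a limit of the assay and not a number. Two fluorinated relatives do give numbers: compound 1 (`Fc1ccccc1-c1nnc(SCc2ccc(Cl)nc2)o1`) shows 9.12 ug/mL and compound 2 (`Fc1ccc(-c2nnc(SCc3ccc(Cl)nc3)o2)cc1`) shows 3.67 ug/mL. Compound 4 (`Clc1ccc(CSc2nnc(-c3ccco3)o2)cn1`) carries furan-2-yl in place of 4-hydroxyphenyl on an aromatic carbon. Three measured steps change this same group: a 2.5-fold lower number from compound 1 to compound 2 (0.40 log units; beyond the scatter), an at least 2.1-fold higher number from compound 1 to compound 3 (0.34 log units; beyond the scatter), and an at least 5.4-fold higher number from compound 2 to compound 3 (0.73 log units; beyond the scatter). Both steps into compound 3 raise the number, so leaving the 4-hydroxyphenyl is expected to lower it by a modest step or more. The estimated change is an at least 2.5-fold lower number from compound 3 to compound 4 (0.39 log units; beyond the scatter) as an expectation. For compound 4 the expected value is 8 ug/mL (estimated range 3 ug/mL to 20 ug/mL).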

Compound 4, half-maximal inhibitory concentration: 14.3 ug/mL
Estimate against measurement, compound 4: 1.8-fold (0.25 log units) below; the range from low to high includes it.
By their numbers in this assay, from the lowest: compound 2; then compounds 1 and 4 (each within the scatter of the next). At a limit, above all of these: compound 3.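

In this assay the step is an at least 1.3-fold lower number from compound 3 to compound 4 (0.14 log units; that floor lies within the scatter), and its true size stays open because the value of compound 3 is a limit of the assay and not a number: the limit of > 20 ug/mL in this assay, at which 1 of the 4 values shown sits.
Against the 2-fluorophenyl group, furan-2-yl shows no change that can be told from the scatter, with a 1.6-fold higher number from compound 1 to compound 4 (0.20 log units; within the scatter). Against the 4-fluorophenyl group the loss is clear, with a 3.9-fold higher number from compound 2 to compound 4 (0.59 log units; beyond the scatter), so a five-membered aromatic ring at this position does not match the best compound shown. On these data alone, whether a 4-aminophenyl or a thiophen-2-yl group here would fall nearer compound 2 or nearer compound 4 remains open.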